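A Fluorophenyl Swap at the Cytotoxicity Limit

A few compounds are considered here, and "the series" means these few. Any claim that something is new, unique, unknown or untested is made for them only; others in the source may bear on it.

Compound 1 `Cc1cc(NC(=O)Nc2ccccc2C(N)=O)c2ccccc2n1`: > 25000 nM
Compound 2 `Cc1cc(NC(=O)Nc2ccc(O)cc2)c2ccccc2n1`: > 25000 nM

In an ADME assay on HEK293 cells (Homo sapiens) for cytotoxicity, with a stated time of 72 h (on this read-out higher numbers stand for an effect only at larger amounts of compound and lower numbers for an effect already at smaller amounts), compound 2 gives > 25000 nM, and this is a limit of the assay, not a number. Compound 1 likewise gives only a limit, > 25000 nM. Neither compound has an exact value, so the two cannot be ranked against each other.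

Compound 3 `Cc1cc(NC(=O)Nc2ccccc2F)c2ccccc2n1` differs from compound 2 in one place, with 2-fluorophenyl in place of 4-hydroxyphenyl on an amide-type nitrogen. Going by the values given here, no measured step shows what such a swap does. Because compound 2 gives the limit > 25000 nM, no change beyond the usual scatter is expected in this assay. The expected step of a number no higher from compound 2 to compound 3 (the limit leaves the size open) is therefore small, with no favoured direction. Compound 3 is estimated at 25000 nM, with an expected range from 12000 nM to 50000 nM, and it may well be reported only as a limit.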

Compound 3, half-maximal effective concentration: > 25000 nM
Compound 3 gave a limit, no number (the forecaster's own chance of this, stated with the estimate: 80%); the middle value sits exactly at the limit.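

Compound 3 also gives only a limit, so the steps to it from compound 1 and compound 2 cannot be read, because all three compounds stop at the same point: the limit of > 25000 nM in this assay, at which 3 of the 3 values shown sit.

In this assay the compounds shown leave open at what amount, if any, compound 1, compound 2 or compound 3 would show an effect.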